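Exchanging the side chain of compound 2 for 1-hydroxyethyl

The source may hold more compounds than are shown below. What is called first, only, known or untested is meant among the compounds shown, and "the series" means these compounds.

Three compounds have been measured in a functional assay on the whole organism (Tail, strain ICR) with Mus musculus as the target, in the tail flick test, with a stated time of 30 min, at a dose of 25 umol/kg by the oral route; a lower number here means a weaker effect, a higher number a stronger effect of the compound at the dose given:
compound 1 `NC(=O)CC[C@H](NC(=O)CN(c1ncnc2c1ncn2C1CCCCO1)C1CC1)C(=O)OCc1ccccc1` gives 47%;
compound 2 `N=C(N)NCCC[C@H](NC(=O)CN(c1nc(Cl)nc2[nH]cnc12)C1CC1)C(=O)O` gives 45.4%;
compound 3 `NCCCC[C@H](NC(=O)CN(c1nc(Cl)nc2[nH]cnc12)C1CC1)C(=O)OCc1ccccc1` gives 26.1%.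

Compound 2 stands close to compound 1, the two values lying within the usual scatter of each other, while its value is well above that of compound 3, a gap that lies beyond the scatter. Going by the values given here, no single-point steps between the measured compounds are available, so the effect of one change at a time is not known here.

Compound 4 `C[C@@H](O)[C@H](NC(=O)CN(c1nc(Cl)nc2[nH]cnc12)C1CC1)C(=O)O` has not yet been measured in this assay. It differs from compound 2 in one place: a group of 3 heavy atoms (2 carbon, 1 oxygen; no ring) in place of a group of 7 heavy atoms (4 carbon, 3 nitrogen; no ring), on a saturated chain carbon bound to an amide-type nitrogen and a carbonyl carbon. Among the compounds with values here, since the three measured values all lie within a moderate span and no step isolates this kind of change, a step from compound 2 to compound 4 is expected to be small, perhaps a modest decrease that may not exceed the scatter. The change from compound 2 to compound 4 is estimated at a number 7.4 percentage points lower from compound 2 to compound 4 (within the scatter). Compound 4 is expected to give 38%, with a range from 20% to 55%.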

Compound 4, a percentage reported as activity, at one dose (the size of the read-out at that dose, not a potency): 18.6%
Compound 4: middle estimate off by 19.4 percentage points, on the high side; the measured number lies below the stated range.
By their numbers in this assay, from the lowest: compounds 4 and 3 (each within the scatter of the next); then compounds 2 and 1 (each within the scatter of the next).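

In this assay, the exchange on the saturated chain carbon bound to an amide-type nitrogen and a carbonyl carbon, with 1-hydroxyethyl in place of the group of 7 heavy atoms, gives a number 26.8 percentage points lower from compound 2 to compound 4 (beyond the scatter), a step beyond the scatter. Going by these compounds alone, this is the first single-place change in the set, and it shows that the group at this position bears on the effect at the dose given, which the earlier compounds, differing in more than one place, could not show. No measurement at hand accounts for the size or direction of this step.

On these data alone, it remains open how a carboxylic acid, a methyl group or a longer hydrocarbon chain at this carbon would perform. A single step also cannot show which feature of the exchanged groups matters.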